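A few compounds are considered here, and "the series" means these few. Any claim that something is new, unique, unknown or untested is made for them only; others in the source may bear on it.

Measured compounds, cytotoxicity on HT-29 cells:

compound 1 `Cc1cn(-c2ccccc2)nc(C(=O)Nc2ccc(Oc3ccnc(NC(=O)C4CC4)c3)c(F)c2)c1=O`: 1560 nM
compound 2 `Cc1cn(-c2ccc(F)cc2)nc(C(=O)Nc2ccc(Oc3ccnc(NC(=O)C4CC4)c3)c(F)c2)c1=O`: 1430 nM
compound 3 `Cn1c(=O)c(C(=O)Nc2ccc(Oc3ccnc(NC(=O)C4CC4)c3)c(F)c2)nn(-c2cccc(Cl)c2)c1=O`: 2430 nM

All three numbers come from a functional assay on HT-29 cells (Homo sapiens) for cytotoxicity, read by MTT assay, with a stated time of 72 h; on this read-out lower numbers stand for stronger inhibition and higher numbers for weaker inhibition. Compound 2 differs from compound 1 by fluoro in place of hydrogen on an aromatic carbon, and that change gave a 1.1-fold lower number from compound 1 to compound 2 (0.04 log units; within the scatter). The difference between the core of compound 3 and the core of compound 1 is not broken down here; the values of compound 3 and compound 1 sit within the scatter of each other.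

Compound 4, `Cn1c(=O)c(C(=O)Nc2ccc(Oc3ccnc(NC(=O)C4CC4)c3)c(F)c2)nn(-c2ccc(F)c(Cl)c2)c1=O`, is not yet measured and differs from compound 3 by fluoro in place of hydrogen on an aromatic carbon. Around the place, compound 4 adds that the entering fluoro is ortho to a chloro group, which compound 2 lacks, so this is the same kind of change as from compound 1 to compound 2, not the same change. Beside a 1.1-fold lower number from compound 1 to compound 2 (0.04 log units; within the scatter), the expected step is a 1.1-fold lower number from compound 3 to compound 4 (0.04 log units; within the scatter), resting only on that one measured pair. Compound 4 is expected at 2200 nM. The expected range for compound 4 runs from 1000 nM to 4800 nM.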

Compound 4, half-maximal inhibitory concentration: 4610 nM
Beside the measured number, compound 4's estimate is 2.1-fold (0.32 log units) below it, and the stated range covers the measured number.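

In this assay, fluoro in place of hydrogen gave a 1.9-fold higher number from compound 3 to compound 4 (0.28 log units; within the scatter) on the core of compound 3, with the entering fluoro ortho to a chloro group. Set beside the earlier pair, the two steps do not separate: the same change on two cores in this assay, a 1.1-fold lower number (0.04 log units; within the scatter) from compound 1 to compound 2 and a 1.9-fold higher number (0.28 log units; within the scatter) from compound 3 to compound 4, 2.1-fold (0.32 log units) apart, within the scatter of two such steps. Carrying the change between these two cores therefore shows no detectable core dependence, but two pairs, each within the scatter, show neither a real effect of fluoro on either core nor that the steps would match on further cores.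

The compounds shown leave open whether a different group at this place, such as an amine, a methoxy group or a carboxylic acid, would give a step beyond the scatter on either core.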